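The compounds below may be only part of what the source reports. "The series", "measured", "known", "first", "only" and "open" are said of these compounds alone.

Measured so far in a functional assay on OVCAR-3 cells (Homo sapiens) for antiproliferative activity, read by WST assay, with a stated time of 72 h, in the absence of a further agent; on this read-out lower numbers stand for stronger inhibition and higher numbers for weaker inhibition:
Compound 1 `CCCCCCCC/C=C\c1c(C)c(/C=C\CCCCCCCC)c2[n+](c1C)CCC2` gives 1100 nM here
Compound 2 `CCCCCCCC/C=C\c1c(C)cc(C)[n+]2c1CCC2` gives 1300 nM here

Compound 1 stands within the scatter of compound 2, so neither stands apart. Compound 3 `CCCCCCCC/C=C\c1c(C)c(/C=C/CCCCCCCC)c2[n+](c1C)CCC2` has the same atoms and bonds as compound 1 (the two compounds have the same atoms and bonds and differ only in configuration as drawn: 1 of 2 stereo elements differ; a double bond is drawn Z in compound 1 and E in compound 3), with a double bond drawn Z in compound 1 and E in compound 3. For the measured compounds named here, the one measured step (a 1.2-fold higher number from compound 1 to compound 2 (0.07 log units; within the scatter)) puts hydrogen in place of dec-1-en-1-yl on an aromatic carbon. Going by the values given here, it is the only guide, as no measured step covers configuration. On that small step, no shift beyond the scatter is expected in this assay here. The estimated step (no change at the digits printed from compound 1 to compound 3 (within the scatter)) is expected to stay within the scatter. Compound 3 is expected at 1100 nM with an estimated range of 550 nM to 2300 nM in this read-out.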

Compound 3, half-maximal inhibitory concentration: 900 nM
Estimate against measurement, compound 3: 1.2-fold (0.09 log units) above; the measured number falls inside the stated range.
By their numbers in this assay, from the lowest: compounds 3, 1 and 2 (each within the scatter of the next).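

In this assay the configuration of one double bond gives a 1.2-fold lower number from compound 1 to compound 3 (0.09 log units; within the scatter). This pair reads configuration alone: the fact that compounds 1 and 3 differ only in the configuration as drawn. The earlier step covered only hydrogen in place of dec-1-en-1-yl, so the series now shows that neither that replacement nor this configuration change moves the number beyond the scatter.

Open, going by these compounds, is whether a saturated decyl chain, a much shorter or longer chain, or a chain ending in an amine or a carboxylic acid would do so. Also open, on these data alone, is whether configuration matters with other groups on the shared core.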